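The compounds below may be only part of what the source reports. "The series", "measured", "known", "first", "only" and "open" are said of these compounds alone.

Compound 1 `O=C1NC(=S)S/C1=C\c1cc(Cl)ccc1OCc1ccccc1`: 5000 nM
Compound 2 `Cc1ccc(OCc2ccccc2)c(/C=C2\SC(=S)NC2=O)c1`: 6000 nM

In a functional assay on A549 cells (Homo sapiens) for inhibition, read by sulforhodamine B assay (on this read-out higher numbers stand for weaker inhibition of growth and lower numbers for stronger inhibition of growth), compound 2 gives 6000 nM, the highest of the two numbers, although its separation from compound 1, a 1.2-fold higher number from compound 1 to compound 2 (0.08 log units; within the scatter), is within the scatter. Compound 3 `COc1ccc(OCc2ccccc2)c(/C=C2\SC(=S)NC2=O)c1` differs from compound 2 by methoxy in place of methyl on an aromatic carbon. Going by the values given here, only one measured step bears on this place on the ring, and it stayed within the scatter; no step exchanges methyl for methoxy. Compound 3 is therefore expected to show no change in this assay beyond the scatter, with a step of no change at the digits printed from compound 2 to compound 3 (within the scatter). The value of compound 3 is estimated at 6000 nM, between 3000 nM and 12000 nM.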

Compound 3, concentration for 50% growth inhibition: 7000 nM
Compound 3: the middle estimate sits 1.2-fold (0.07 log units) below what was measured; the measured number falls inside the stated range.
By their numbers in this assay, from the lowest: compounds 1, 2 and 3 (each within the scatter of the next).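

In this assay methoxy on this aromatic carbon gives a 1.2-fold higher number from compound 2 to compound 3 (0.07 log units; within the scatter) and, set against chloro, a 1.4-fold higher number from compound 1 to compound 3 (0.15 log units; within the scatter) on the same carbon. Chloro, methyl and methoxy therefore all read alike at this place, and the added oxygen with its hydrogen-bond acceptor brings no step beyond the scatter, something the earlier pair could not show. No measurement at hand accounts for this sameness.

The compounds shown leave open whether an amine, a carboxylic acid or a longer chain at this place would also read alike.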